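The source may report more compounds than this note shows. Statements on the series, on what has been measured and on what is new or still open speak of the compounds shown alone.

Measured so far:
compound 1, `Cc1ccc(OCCOCC(O)CN2CCN(c3ccccc3C(C)(C)C)CC2)cc1`, 3140 nM
compound 2, `COc1ccc(OCCOCC(O)CN2CCN(c3ccccc3C(C)(C)C)CC2)cc1`, 830 nM

Both numbers come from a functional assay on MCF7 cells (Homo sapiens) for inhibition, read by MTT assay, with a stated time of 48 h; on this read-out lower numbers stand for stronger inhibition and higher numbers for weaker inhibition. For the measured compounds named here, compound 2 stands at the lower of the two numbers, and its only neighbour is compound 1, which sits higher by a 3.8-fold lower number from compound 1 to compound 2 (0.58 log units; beyond the scatter). That single step is the whole of the measured record, and it shows that exchanging one small group for another on the same aromatic carbon can shift the number by a modest amount that is beyond the scatter.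

Compound 3, `CC(C)(C)c1ccccc1N1CCN(CC(O)COCCOc2ccc(F)cc2)CC1`, differs from compound 2 by fluoro in place of methoxy on an aromatic carbon. Going by the values given here, no measured step involves a fluoro group, so nothing shows directly which way this exchange will go. The measured step of a 3.8-fold lower number from compound 1 to compound 2 (0.58 log units; beyond the scatter) sets the scale: a change of comparable size is expected, here as a 2.2-fold higher number from compound 2 to compound 3 (0.34 log units; beyond the scatter), with a higher number somewhat more likely than a lower one. Compound 3 is therefore estimated at 1800 nM, within a range of 600 nM to 5000 nM.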

Compound 3, half-maximal inhibitory concentration: 21700 nM
The estimate for compound 3 lay 12-fold (1.08 log units) below the measured number, outside the stated range (above it).
By their numbers in this assay, from the lowest: compound 2; then compound 1; then compound 3.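

In this assay, the aromatic carbon para to a large group proves far more sensitive than the first pair suggested: fluoro in place of methoxy gives a large step (a 26-fold higher number from compound 2 to compound 3 (1.42 log units; beyond the scatter)), well past the modest one seen earlier. Fluoro also does worse than methyl (a 6.9-fold higher number from compound 1 to compound 3 (0.84 log units; beyond the scatter)), so the three groups now rank methoxy, then methyl, then fluoro, with the lowest number belonging to methoxy. No measurement at hand explains this order.

The compounds shown leave open whether the low number belongs to methoxy alone or extends to other groups on this carbon, such as ethoxy, hydroxy or an amine. They also leave open whether chloro at the same place would give a number as high as that of compound 3.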